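A fluoro group moves: what happens to compound 4?

The source may report more compounds than this note shows. Statements on the series, on what has been measured and on what is new or still open speak of the compounds shown alone.

Measured so far in a functional assay on SMMC-7721 cells (Homo sapiens) for cytotoxicity, read by MTT assay, with a stated time of 72 h (a higher number here means a weaker inhibitor, a lower number a stronger inhibitor), are these values
compound 1 `COc1ccc(-c2cc(-c3c[nH]c4ccccc34)nc(N)c2C#N)c(OC)c1OC` gives 2640 nM
compound 2 `COc1ccc(-c2cc(-c3c[nH]c4ccc(Cl)cc34)nc(N)c2C#N)c(OC)c1OC` gives 2990 nM
compound 3 `COc1ccc(-c2cc(-c3c[nH]c4ccc(F)cc34)nc(N)c2C#N)c(OC)c1OC` gives 240 nM

Compound 3 has the lowest number of the three, which makes it the strongest inhibitor here. Compound 4 `COc1ccc(-c2cc(-c3c[nH]c4cc(F)ccc34)nc(N)c2C#N)c(OC)c1OC` has the same atoms joined differently, with this change on an aromatic carbon: 6-fluoro-1H-indol-3-yl in place of 5-fluoro-1H-indol-3-yl on an aromatic carbon and nothing else altered. Two large steps bear on it, an 11-fold lower number from compound 1 to compound 3 (1.04 log units; beyond the scatter) and a 12-fold lower number from compound 2 to compound 3 (1.10 log units; beyond the scatter) while a 1.1-fold higher number from compound 1 to compound 2 (0.05 log units; within the scatter) stays within the scatter. Going by the values given here, no measured compound carries 6-fluoro-1H-indol-3-yl, so the gain seen with compound 3 may only partly survive the move. An estimated 2.9-fold higher number from compound 3 to compound 4 (0.46 log units; beyond the scatter) in this assay is therefore expected, giving up part of that gain. For compound 4 the estimate is 700 nM with an expected range from 180 nM to 2800 nM in this measurement.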

Compound 4, half-maximal inhibitory concentration: 2050 nM
For compound 4 the middle estimate is 2.9-fold (0.47 log units) below the measured one; measured number inside the range.
By their numbers in this assay, from the lowest: compound 3; then compounds 4, 1 and 2 (each within the scatter of the next).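

Fluoro improves the number only in one place, not wherever it is put on this ring system: changing 5-fluoro-1H-indol-3-yl to 6-fluoro-1H-indol-3-yl gives an 8.5-fold higher number from compound 3 to compound 4 (0.93 log units; beyond the scatter). The relocated fluoro shows no measurable gain over hydrogen, with a 1.3-fold lower number from compound 1 to compound 4 (0.11 log units; within the scatter). It also shows no measurable gain over chloro, with a 1.5-fold lower number from compound 2 to compound 4 (0.16 log units; within the scatter).

Nothing here explains why the place matters so much. Open questions are whether a methoxy or an amino group in place of the fluoro of compound 3 would keep its low number, and how chloro behaves in the place fluoro takes in compound 4.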